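Naphthalen-1-yl for 2-methoxyphenyl: the step to compound 3

This account rests on a few compounds, and the source may have more. Where it says the series, first, only, none or still open, it means among the compounds named here.

Of the compounds shown here, two so far carry numbers in a functional assay on DU-145 cells (Homo sapiens) for inhibition, read by MTT assay, with a stated time of 72 h; on this read-out lower numbers stand for stronger inhibition and higher numbers for weaker inhibition. Compound 1 (`COC(=O)CCCCCCC(=O)Nc1cccc(OS(=O)(=O)C2CC3OC2C(c2ccc(O)cc2)=C3c2ccc(O)cc2)c1`) gives 19300 nM. Compound 2 (`COc1ccccc1OS(=O)(=O)C1CC2OC1C(c1ccc(NC(=O)CCCCCCC(=O)NO)cc1)=C2c1ccc(O)cc1`) gives 44700 nM, the higher of the two numbers, and its gap to compound 1 lies beyond the usual scatter. These two compounds differ in more than one place, so their gap does not isolate the effect of any single change.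

Compound 3 (`O=C(CCCCCCC(=O)Nc1ccc(C2=C(c3ccc(O)cc3)C3CC(S(=O)(=O)Oc4cccc5ccccc45)C2O3)cc1)NO`) is not yet measured. It differs from compound 2 in one place, with naphthalen-1-yl in place of 2-methoxyphenyl on an oxygen whose other neighbour is the sulfonyl sulfur: naphthalen-1-yl in place of 2-methoxyphenyl on an oxygen. Cut one bond further out, the same difference reads 2-methoxyphenoxy to (naphthalen-1-yl)oxy.

Going by the values given here, no measured step covers this place, so the expectation starts from compound 2 at 44700 nM. In this assay, no step beyond the scatter is expected, with at most a slight drift towards a lower number. The expected step, a 1.5-fold lower number from compound 2 to compound 3 (0.17 log units; within the scatter), stays within the usual scatter. Compound 3 is estimated at 30000 nM, with an expected range of 10000 nM to 80000 nM.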

Compound 3, half-maximal inhibitory concentration: 8570 nM
Beside the measured number, compound 3's estimate is 3.5-fold (0.54 log units) above it; the whole stated range lies above it.
By their numbers in this assay, from the lowest: compound 3; then compound 1; then compound 2.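

In this assay, going by these compounds alone, the oxygen whose other neighbour is the sulfonyl sulfur is the first place where a single change can be read, and naphthalen-1-yl in place of 2-methoxyphenyl gives a 5.2-fold lower number from compound 2 to compound 3 (0.72 log units; beyond the scatter). The group on this oxygen therefore moves the number beyond the scatter, with the change taking the count from one six-membered aromatic ring of carbon only to two and from one hydrogen-bond acceptor to none. Nothing measured here accounts for the size or direction of this step.

The compounds shown leave open whether the lower number goes with the second aromatic ring or with the loss of the methoxy oxygen, since the two change together in this one step. A plain phenyl or a benzyl group on the same oxygen could help separate the two, and for now the effect at this position rests on a single pair of compounds.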